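Bromo Added to a Sulfonamide Inhibitor

The source may report more compounds than this note shows. Statements on the series, on what has been measured and on what is new or still open speak of the compounds shown alone.

Of the compounds shown here, two sharing one core have been tested in an assay on isolated protein for inhibition of alkaline phosphatase, tissue-nonspecific isozyme (Bos taurus), read by spectrophotometry, with stated times of 10 min and 30 min; a higher number here means a weaker inhibitor, a lower number a stronger inhibitor. Compound 1 `CCOC1Oc2ccc(Br)cc2C(=O)/C1=C\Nc1ccc(S(N)(=O)=O)cc1` gives 48000 nM. Compound 2 `CCOC1Oc2ccccc2C(=O)/C1=C\Nc1cccc(S(N)(=O)=O)c1` gives 41000 nM, the lower of the two numbers, but its gap to compound 1 lies within the scatter of repeated measurements, so the two cannot be told apart on these data. Going by the values given here, compound 1 and compound 2 differ in more than one place, so no single step between them can be read off. Compound 3 `CCOC1Oc2ccc(Br)cc2C(=O)/C1=C\Nc1cccc(S(N)(=O)=O)c1` has not yet been measured. It differs from compound 2 in one way: bromo in place of hydrogen on an aromatic carbon. Compound 1 already carries this bromo, and its number in this assay sits close to that of compound 2. A step beyond the scatter is therefore not expected, and the estimate means a step of a 1.1-fold higher number from compound 2 to compound 3 (0.04 log units; within the scatter). Compound 3 is expected to give about 45000 nM, with a likely range from 20000 nM to 100000 nM.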

Compound 3, inhibition constant: 44000 nM
For compound 3 the middle estimate is 1.0-fold (0.01 log units) above the measured one; the range from low to high includes it.
By their numbers in this assay, from the lowest: compounds 2, 3 and 1 (each within the scatter of the next).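

Bromo in place of hydrogen on this aromatic carbon, para to a fused ring, gives a 1.1-fold higher number from compound 2 to compound 3 (0.03 log units; within the scatter) in this assay. Going by these compounds alone, this is the first reading of the bromo alone, with the rest of the molecule held the same; compound 1 could not give it, as it differs from compound 2 in more than one place. At this position, then, one added bromine atom leaves a step that cannot be told from the scatter. No measurement shown here bears on the reason for this result.

On these data alone, whether an amine, a carboxylic acid or a longer chain on this same carbon would give a step beyond the scatter remains open. So does whether bromo on another carbon of this ring would behave in the same way.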